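The source may hold more compounds than are shown below. What is called first, only, known or untested is meant among the compounds shown, and "the series" means these compounds.

Compound 1 `CC1=C(C(=O)C2CC2)C(c2cccs2)NC(=O)N1`: 1%
Compound 2 `CCSC(=O)C1=C(C)NC(=O)NC1c1ccco1`: 29%

For the measured compounds named here, in an assay on membranes from HEK293 cells for displacement of a labelled ligand from adenosine receptor A2b (Homo sapiens), read by scintillation counting, with a stated time of 30 min, tested at 1 uM (on this read-out lower numbers stand for less inhibition and higher numbers for more inhibition at the one concentration tested (going by the name of the read-out)), compound 2 gives 29%, the higher of the two numbers measured so far; compound 1 gives 1%, lower by a margin beyond the usual scatter. Going by the values given here, compound 1 and compound 2 differ in more than one place, so no single step is known between them. Compound 3 `CCSC(=O)C1=C(C)NC(=O)NC1c1cccs1` differs from compound 2 by thiophen-2-yl in place of furan-2-yl on a saturated ring carbon. Among the compounds with values here, no measured step covers this change; the expected effect in this assay is a slight downward step of a number 7 percentage points lower from compound 2 to compound 3 (within the scatter), within the usual scatter. Compound 3 is expected to give 22%, in a range from 5% to 40%.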

Compound 3, a percentage reported as inhibition, at one concentration (the size of the read-out at that concentration, not a potency): 1%
Compound 3: middle estimate off by 21 percentage points, on the high side; measured number outside the range, below it.
By their numbers in this assay, from the lowest: compounds 1 and 3 (each within the scatter of the next); then compound 2.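

In this assay, a number 28 percentage points lower from compound 2 to compound 3 (beyond the scatter) comes with thiophen-2-yl in place of furan-2-yl on the saturated ring carbon, so this position responds to an exchange between two five-membered aromatic rings with the (ethylsulfanyl)carbonyl group held. With thiophen-2-yl held, no change at the digits printed from compound 1 to compound 3 (within the scatter) comes with ethylsulfanyl in place of cyclopropyl on the carbonyl carbon, so that exchange shows no effect here. Nothing available bears on the reason for the step at the ring carbon.

Open, from the compounds shown here alone, is whether cyclopropyl on the carbonyl carbon paired with furan-2-yl keeps the number of compound 2. Also open, going by these compounds, is how a phenyl ring on the ring carbon or a longer chain on the sulfur would read.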